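The source may hold more compounds than are shown below. What is called first, only, known or untested is meant among the compounds shown, and "the series" means these compounds.

In a functional assay on HCC1806 cells (Homo sapiens) for inhibition, read by sulforhodamine B assay, tested at 10 uM (a higher number here means more inhibition at the concentration tested (going by the name of the read-out), a lower number less inhibition), compound 1 `CN1CCN(c2ccc(C3=NNC(c4ccc(N(C)C)cc4)C3)cc2)CC1` gives 31.2%, compound 2 `CN(C)c1ccc(C2CC(c3ccc(-n4cncn4)cc3)=NN2)cc1` gives 6.8%, and compound 3 `CN1CCN(c2ccc(C3=NN(S(=O)(=O)C4CC4)C(c4ccc(N(C)C)cc4)C3)cc2)CC1` gives 4.7%. Among these three numbers compound 2 stands second highest; its value and that of compound 3 lie within the scatter of each other, so no order between them can be read, while compound 1 sits clearly higher, as the step of a number 24.4 percentage points lower from compound 1 to compound 2 (beyond the scatter) shows. The unmeasured compound 4 `CN(C)c1ccc(C2CC(c3ccc(-n4cncn4)cc3)=NN2S(=O)(=O)c2ccc(F)cc2)cc1` differs from compound 2 in one place: (4-fluorophenyl)sulfonyl in place of hydrogen on an amine nitrogen in a ring. The closest measured step is a number 26.5 percentage points lower from compound 1 to compound 3 (beyond the scatter), in which a cyclopropylsulfonyl in place of hydrogen on an amine nitrogen in a ring lowered the read-out markedly. A similar lowering in this assay is plausible for compound 4, but the value of compound 2 is already near the floor of the scale, so the room for a further drop is small. Compound 4 is therefore expected to give 4%, within a range of -8% to 15%. The expected step of a number 2.8 percentage points lower from compound 2 to compound 4 (within the scatter) is thus estimated to stay within the scatter.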

Compound 4, a percentage reported as inhibition, at one concentration (the size of the read-out at that concentration, not a potency): 24.1%
Compound 4: the middle estimate sits 20.1 percentage points below what was measured, outside the stated range (above it).
By their numbers in this assay, from the lowest: compounds 3 and 2 (each within the scatter of the next); then compounds 4 and 1 (each within the scatter of the next).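

On the amine nitrogen in the ring, adding a sulfonyl group does not have to lower the read-out in this assay: (4-fluorophenyl)sulfonyl gives an upward step (a number 17.3 percentage points higher from compound 2 to compound 4 (beyond the scatter)), whereas cyclopropylsulfonyl at the same nitrogen gave a downward one (a number 26.5 percentage points lower from compound 1 to compound 3 (beyond the scatter)). These two steps differ in both the sulfonyl group added and the group on the rest of the molecule, 1H-1,2,4-triazol-1-yl in one and 4-methylpiperazin-1-yl in the other, so neither difference alone can account for the change of direction. No measurement available here explains why the read-out goes up in this case.

On these data alone, it remains open what (4-fluorophenyl)sulfonyl would do on compound 1, and what cyclopropylsulfonyl would do on compound 2. Also open, as far as these compounds go, is how an acetyl or a methylsulfonyl group on this nitrogen would compare.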